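The source may report more compounds than this note shows. Statements on the series, on what has been measured and on what is new or still open speak of the compounds shown alone.

Compound 1, `CCc1nc(-c2ccc(Cl)cc2Cl)c(CC)nc1NC(CC)CC`: 4.1 nM
Compound 2, `CCc1nc(NC(CC)CC)c(I)nc1-c1ccc(Cl)cc1Cl`: 12 nM
Compound 3, `CCc1nc(-c2ccc(OC)cc2C(F)(F)F)c(CC)nc1NC(CC)CC`: 4.4 nM

In an assay on IMR-32 cells for displacement of a labelled ligand from corticotropin-releasing factor receptor 1 (Homo sapiens), read by scintillation counting, with a stated time of 2 h (a higher number here means a weaker inhibitor, a lower number a stronger inhibitor), compound 2 has the highest of these three numbers, and its gaps to compound 1 and to compound 3 both lie beyond the scatter. Compound 4, `CCc1nc(NC(CC)CC)cnc1-c1ccc(Cl)cc1Cl`, differs from compound 2 in one place: hydrogen in place of iodo on an aromatic carbon. For the measured compounds named here, the only measured step touching this carbon is a 2.9-fold higher number from compound 1 to compound 2 (0.47 log units; beyond the scatter), a modest move when one group replaces another there. Going by the values given here, no measured compound carries only hydrogen at this carbon, so the direction is uncertain. Since compound 1 gives 4.1 nM and compound 2 gives 12 nM, both with a group in place, losing it is expected to raise the number further. Compound 4 is expected to show a 2.5-fold higher number from compound 2 to compound 4 (0.40 log units; beyond the scatter). The estimate for compound 4 is 30 nM, within 10 nM to 100 nM.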

Compound 4, inhibition constant: 545 nM
Beside the measured number, compound 4's estimate is 18-fold (1.26 log units) below it; the whole stated range lies below it.
By their numbers in this assay, from the lowest: compounds 1 and 3 (each within the scatter of the next); then compound 2; then compound 4.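

Putting a hydrogen at this carbon costs far more than swapping one group for another there: in this assay, replacing iodo gives a 45-fold higher number from compound 2 to compound 4 (1.66 log units; beyond the scatter), and replacing ethyl gives a 130-fold higher number from compound 1 to compound 4 (2.12 log units; beyond the scatter). Both steps are much larger than the change between the two groups, a 2.9-fold higher number from compound 1 to compound 2 (0.47 log units; beyond the scatter), so in these three compounds having either group at this carbon matters more than which of the two it is. No measurement here bears on the cause of this loss.

On these data alone, what a methyl group, a chloro group, an amine or a nitrile would give at this carbon stays open.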